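The compounds below may be only part of what the source reports. "The series", "measured", "known", "first", "only" and "open" are said of these compounds alone.

Measured compounds:

Compound 1, `CCN(CC)CC(=O)OC1CC2(N(C)C)CC(c3ccccc3)C1C(c1ccccc1)C2`: in an ADME assay on L6 cells (Rattus norvegicus) for cytotoxicity (a higher number here means a weaker inhibitor, a lower number a stronger inhibitor), compound 1 gives 30100 nM.
Compound 2, `CCN(CC)CC(=O)OC1CC2(N3CCCC3)CC(c3ccccc3)C1C(c1ccccc1)C2`: in this assay compound 2 gives 49000 nM.
Compound 3, `CN(C)C12CC(OC(=O)CCN3CCCC3)C(C(c3ccccc3)C1)C(c1ccccc1)C2`: in this assay compound 3 gives 26000 nM.

Compound 4, `O=C(CCN1CCCC1)OC1CC2(N3CCCC3)CC(c3ccccc3)C1C(c1ccccc1)C2`, has not yet been measured in this assay. It differs from compound 3 in one place: pyrrolidin-1-yl in place of dimethylamino on a saturated ring carbon. The same change has already been made once among the measured compounds, from compound 1 to compound 2: pyrrolidin-1-yl in place of dimethylamino on a saturated ring carbon. That step gave a 1.6-fold higher number from compound 1 to compound 2 (0.21 log units; within the scatter).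

The two cores are not identical. Compound 3 differs from compound 1 in the ester side: (pyrrolidin-1-yl)methyl in place of diethylamino on a saturated chain carbon bound to a carbonyl carbon. That change made a 1.2-fold lower number from compound 1 to compound 3 (0.06 log units; within the scatter). As a result the surroundings of the place are not the same word for word: in the pair of compound 1 and compound 2 there are two ring bonds from the ring atom that bears a (((diethylamino)methyl)carbonyl)oxy group, whereas in the pair of compound 3 and compound 4 there are two ring bonds from the ring atom that bears a ((2-(pyrrolidin-1-yl)ethyl)carbonyl)oxy group. The change from compound 3 to compound 4 is therefore the same kind of change as that from compound 1 to compound 2, not the same change.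

Within the data shown here, with only one earlier example of this kind, the expectation rests on compound 3 with 26000 nM and on the step of a 1.6-fold higher number from compound 1 to compound 2 (0.21 log units; within the scatter). The estimated step is a 1.5-fold higher number from compound 3 to compound 4 (0.19 log units; within the scatter). Compound 4 is expected to give about 40000 nM in this assay, most likely between 20000 nM and 80000 nM.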

Compound 4, half-maximal inhibitory concentration: 21900 nM
Compound 4: middle estimate off by 1.8-fold (0.26 log units), on the high side, and the stated range covers the measured number.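

In this assay, pyrrolidin-1-yl in place of dimethylamino gave a 1.2-fold lower number from compound 3 to compound 4 (0.07 log units; within the scatter), and the step on the core of compound 3 agrees with the earlier one on the core of compound 1: the same change on two cores in this assay, a 1.6-fold higher number (0.21 log units; within the scatter) from compound 1 to compound 2 and a 1.2-fold lower number (0.07 log units; within the scatter) from compound 3 to compound 4, 1.9-fold (0.29 log units) apart, within the scatter of two such steps
The change on the ester side, (pyrrolidin-1-yl)methyl in place of diethylamino, gave a 2.2-fold lower number from compound 2 to compound 4 (0.35 log units; beyond the scatter), a modest step beyond the scatter, yet it too does not differ from its counterpart on the other core: the same change on two cores in this assay, a 1.2-fold lower number (0.06 log units; within the scatter) from compound 1 to compound 3 and a 2.2-fold lower number (0.35 log units; beyond the scatter) from compound 2 to compound 4, 1.9-fold (0.29 log units) apart, within the scatter of two such steps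
So each change can be carried from one core to the other in these four compounds without a difference that can be told from the scatter, but with only two examples of each change and such small steps, this does not show that the changes are independent of the core in general, since a small dependence could stay hidden in the scatter.

What the compounds shown leave open is whether a larger step would appear with a piperidin-1-yl or morpholin-4-yl group on the saturated ring carbon. From the compounds shown here alone, it is also open whether a longer chain on the ester side, or a primary amine at its end, would carry over between the cores as these changes do.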